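Vinyl for methyl on the five-membered ring of compound 3

A few compounds are considered here, and "the series" means these few. Any claim that something is new, unique, unknown or untested is made for them only; others in the source may bear on it.

Measured compounds:
compound 1 `CONc1ncnc2c1ncn2[C@H]1C[C@H](OP(=O)(O)O)[C@@H](COP(=O)(O)O)O1`: > 100000 nM
compound 2 `CNc1nc(N)nc2c1ncn2[C@H]1C[C@H](OP(=O)(O)O)[C@@H](COP(=O)(O)O)O1`: 1850 nM
compound 3 `Cc1nc2c(N)ncnc2n1[C@H]1C[C@H](OP(=O)(O)O)[C@@H](COP(=O)(O)O)O1`: 75100 nM

In a functional assay on cell membranes for antagonist activity at P2Y purinoceptor 1 (Meleagris gallopavo) (a higher number here means a weaker inhibitor, a lower number a stronger inhibitor), compound 1 gives only a limit, > 100000 nM, not a number. Compound 2 gives 1850 nM in this assay. Compound 3 gives 75100 nM in this assay, and this is the highest of the two numbers actually read; the gap to compound 2 lies well beyond the scatter, so compound 3 is the weaker inhibitor of the two. One of the three values shown sits at the limit of > 100000 nM in this assay, at which 1 of the 3 values shown sits.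

Compound 4 `C=Cc1nc2c(N)ncnc2n1[C@H]1C[C@H](OP(=O)(O)O)[C@@H](COP(=O)(O)O)O1` has not yet been measured in this assay. It differs from compound 3 in one place: vinyl in place of methyl on an aromatic carbon. Going by the values given here, no measured pair in this set changes the same place, so no measured step gives a size for it. The two groups are alike in what they carry, and the expectation is therefore a step of no more than modest size, if any, beyond the scatter. The estimate for compound 4 in this assay is 60000 nM, within a range from 15000 nM to 200000 nM. This estimate means a step of a 1.3-fold lower number from compound 3 to compound 4 (0.10 log units; within the scatter), that is, compound 4 is expected to stay close to compound 3.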

Compound 4, half-maximal inhibitory concentration: 30700 nM
Beside the measured number, compound 4's estimate is 2.0-fold (0.29 log units) above it, within the range that was stated.
By their numbers in this assay, from the lowest: compound 2; then compound 4; then compound 3. At a limit, above all of these: compound 1.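

In this assay, the aromatic carbon between two ring nitrogen atoms, next to the ring atom that bears a large group, proves responsive to what it carries: vinyl in place of methyl gives a 2.4-fold lower number from compound 3 to compound 4 (0.39 log units; beyond the scatter). Going by these compounds alone, this is the first measured step at this place in the set, and it shows that a second carbon with a double bond outside aromatic rings is accepted there, moving the number modestly towards a stronger inhibitor rather than away from it. Nothing measured here gives a reason for this step.

As far as these compounds go, it remains open whether the added carbon or the double bond accounts for the step, a question that an ethyl group at this place would separate. Also open, from the compounds shown here alone, is how a longer chain, a phenyl ring or an amine would read at the same carbon, and whether vinyl in place of methyl would give a step of similar size on a core carrying other groups.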